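The compounds below may be only part of what the source reports. "The series", "measured", "known", "first", "only" and "open" are said of these compounds alone.

Measured compounds:
compound 1, `COc1ccc(C(=O)NNC(=O)c2ccc3[nH]c(-c4ccc([N+](=O)[O-])o4)nc3c2)cc1OC`, gives 15.6 ug/mL in a functional assay on K562 cells (Homo sapiens) for inhibition, read by sulforhodamine B assay, with a stated time of 48 h; a higher number here means a weaker inhibitor of growth, a lower number a stronger inhibitor of growth.
compound 2, `O=C(NNC(=O)c1ccc2[nH]c(-c3ccc([N+](=O)[O-])o3)nc2c1)c1cccc(Oc2ccccc2)c1`, gives > 7.8 ug/mL in this assay.

The value of compound 2 is a limit of the assay and not a number, so where compound 2 stands among the numbers shown is not fixed: compound 1 is the only compound with a measured figure, and the limit of > 7.8 ug/mL in this assay, at which 1 of the 2 values shown sits, covers the other. The change to compound 3, `O=C(NNC(=O)c1ccc2[nH]c(-c3ccc([N+](=O)[O-])o3)nc2c1)c1ccccc1`, is hydrogen in place of phenoxy on an aromatic carbon. For the measured compounds named here, no step between measured compounds exists for this change, so the expected direction rests on the shared core alone. Across this assay the expectation is a step of modest size, if any, with a weakening of growth inhibition not ruled out, since compound 1 with its dimethoxy pattern already sits at a high concentration. For compound 3 the estimate is 20 ug/mL, within 8 ug/mL to 60 ug/mL, which is the expected step that the limit leaves unreadable from compound 2 to compound 3.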

Compound 3, concentration for 50% growth inhibition: 15.6 ug/mL
Beside the measured number, compound 3's estimate is 1.3-fold (0.11 log units) above it; the range from low to high includes it.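

In this assay, phenyl in place of 3,4-dimethoxyphenyl on the carbonyl carbon gives no change at the digits printed from compound 1 to compound 3 (within the scatter). For this pair, the two methoxy groups make no readable difference to growth inhibition, and compound 3 supplies a plain phenyl reference point for the series. The step from compound 2 cannot be read, because the value of compound 2 is a limit and not a number: the limit of > 7.8 ug/mL in this assay, at which 1 of the 3 values shown sits.

On these data alone, whether phenoxy in place of hydrogen strengthens or weakens growth inhibition therefore stays open, as does whether a single methoxy group would match the pair in compound 1. Also open, as far as these compounds go, is how an amine or a carboxylic acid on the phenyl ring would shift the figure against compound 3.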